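Working notes: thioether substituent change, compound 2 to compound 3

This account rests on a few compounds, and the source may have more. Where it says the series, first, only, none or still open, it means among the compounds named here.

Measured so far:
compound 1 `COc1ccc(-n2c(SCc3ccc(C)cc3)nnc2-c2cc(OC)c(OC)c(OC)c2)cc1` — 56500 nM
compound 2 `COc1cc(-c2nnc(SCc3ccc(C)cc3)n2-c2ccc(N(C)C)cc2)cc(OC)c1OC` — 37300 nM

In a functional assay on PC-3 cells (Homo sapiens) for inhibition, read by MTT assay, with a stated time of 48 h (on this read-out higher numbers stand for weaker inhibition and lower numbers for stronger inhibition), compound 2 gives the lowest of the two numbers, though the nearest, compound 1, differs only by a 1.5-fold lower number from compound 1 to compound 2 (0.18 log units; within the scatter), a dimethylamino in place of methoxy on an aromatic carbon. Compound 3 `COc1ccc(NC(=O)CSc2nnc(-c3cc(OC)c(OC)c(OC)c3)n2-c2ccc(N(C)C)cc2)cc1` is not yet measured; it differs from compound 2 by (4-methoxyphenyl)carbamoyl in place of 4-methylphenyl on a saturated chain carbon bound to a sulfur. Going by the values given here, no measured step touches this position, so nothing directly bears on it, and the one measured step was within the scatter. The expectation is therefore no change beyond the scatter, a 1.2-fold lower number from compound 2 to compound 3 (0.07 log units; within the scatter). For compound 3 the estimate is 32000 nM, range 10000 nM to 100000 nM.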

Compound 3, half-maximal inhibitory concentration: 56100 nM
Beside the measured number, compound 3's estimate is 1.8-fold (0.24 log units) below it, within the range that was stated.
By their numbers in this assay, from the lowest: compounds 2, 3 and 1 (each within the scatter of the next).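

In this assay, the change on the saturated chain carbon bound to a sulfur gives a 1.5-fold higher number from compound 2 to compound 3 (0.18 log units; within the scatter). The exchange brings in a carbonyl and an amide hydrogen and keeps one six-membered aromatic ring, yet the number stays within the scatter, so this position shows no measurable response to this change. Nothing measured bears on why.

As far as these compounds go, the amide and the methoxy enter together, so their separate contributions remain open. Also open, from the compounds shown here alone, is whether a basic amine, a carboxylic acid or a longer chain at this place would move the number.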